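Swapping methyl for chloro on an aromatic ring

The source may hold more compounds than are shown below. What is called first, only, known or untested is meant among the compounds shown, and "the series" means these compounds.

In a functional assay on MCF7 cells (Homo sapiens) for cytotoxicity, read by MTT assay, with a stated time of 72 h (on this read-out lower numbers stand for stronger inhibition and higher numbers for weaker inhibition), compound 1 `CNC(=O)c1cc(Oc2ccc(NC(=O)c3nccc(-c4ccccc4)n3)cc2)ccn1` gives 39100 nM and compound 2 `CNC(=O)c1cc(Oc2ccc(NC(=O)c3cc(-c4ccc(C)cc4)ncn3)cc2)ccn1` gives 34600 nM so the two sit within the scatter of each other. Compound 3 `CNC(=O)c1cc(Oc2ccc(NC(=O)c3nccc(-c4cccc(Cl)c4)n3)cc2)ccn1` gives > 100000 nM as its result, which is a limit of the assay and not a number.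

Compound 4 `CNC(=O)c1cc(Oc2ccc(NC(=O)c3cc(-c4ccc(Cl)cc4)ncn3)cc2)ccn1` has not been measured yet. It differs from compound 2 by a single exchange, chloro in place of methyl on an aromatic carbon in which chloro takes the place of methyl on an aromatic carbon, turning 4-methylphenyl into 4-chlorophenyl.

Going by the values given here, one measured step bears on this exchange: an at least 2.5-fold higher number from compound 1 to compound 3 (0.40 log units; beyond the scatter) for chloro in place of hydrogen on an aromatic carbon. As far as these compounds go, that step ends at a limit, so its true size stays open. It is also only a loose guide, as chloro replaces hydrogen there rather than methyl, and on the core of compound 1 rather than that of compound 2.

A small move towards higher numbers is therefore expected, and the estimated step is a 1.3-fold higher number from compound 2 to compound 4 (0.11 log units; within the scatter) in this assay which may well stay within the scatter. Compound 4 is expected at 45000 nM with 17000 nM to 100000 nM as the estimated range.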

Compound 4, half-maximal inhibitory concentration: > 100000 nM
Compound 4 gave a limit, no number; the forecaster's own chance of this, stated with the estimate: 20%; middle value at least 2.2-fold (0.34 log units) from the limit.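

In this assay, the exchange of methyl for chloro on the aromatic ring gives an at least 2.8-fold higher number from compound 2 to compound 4 (0.46 log units; beyond the scatter), so a change of one heavy atom at this place is enough to move the result beyond the scatter. The earlier compounds shown here showed chloro only in place of hydrogen, on a different core, as an at least 2.5-fold higher number from compound 1 to compound 3 (0.40 log units; beyond the scatter); this result shows a step in the same direction for chloro in place of methyl, on the core of compound 2. Compound 3 and compound 4 both stop at the same limit of the assay, which is not a number, so the true size of each step stays open and the two steps cannot be ranked: the limit of > 100000 nM in this assay, at which 2 of the 4 values shown sit.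

The compounds shown leave open how other groups at this place on the core of compound 2, such as a fluoro, a methoxy or an amine, would read, and whether any of them would give a lower number than compound 2. They also leave open whether methyl in place of chloro would act the same way on the core of compound 1, and they give no reason for either step.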